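Unsaturation in the amide tail and platelet inhibition

A few compounds are considered here, and "the series" means these few. Any claim that something is new, unique, unknown or untested is made for them only; others in the source may bear on it.

Working notes on a series of unsaturated amides tested in a functional assay on cells (Platelet, Oryctolagus cuniculus) for inhibition, read by turbidimetry, with a stated time of 3 min, tested at 50 ug/mL; a higher number here means a weaker effect of the compound at the concentration tested, a lower number a stronger effect. Three compounds carry numbers. Compound 1 `C/C=C/C=C/C=C\CC/C=C/C=C/C(=O)NC(C)(C)O` gives 19.9%. Compound 2 `CCCCCCCCC/C=C/C=C/C(=O)NCC(C)(C)O` gives 58.3%, the highest of the three numbers, beyond the scatter from compound 1 and also from compound 3 `C=CCCC1(CCC=C)C(=O)Nc2ccccc2C1OC`, which gives 0%. For the measured compounds named here, no two of these differ in a single place, so no step between measured compounds can be read off; what the numbers show is that compound 2 stands apart with the weakest effect of the three at the tested concentration.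

Compound 4 `CC/C=C\C/C=C\CC/C=C/C=C/C(=O)NCC(C)(C)O` has not been measured. It differs from compound 2 in one place: hepta-1,4-dien-1-yl in place of heptyl on a saturated chain carbon, two bonds along the chain from a double-bonded chain carbon. The entering group carries double bonds, as does the chain of compound 1, whose number 19.9% is the lower one. Going by the values given here, since no measured step of this kind exists, the expectation rests on that comparison alone. A downward step beyond the scatter is expected, a number 23.3 percentage points lower from compound 2 to compound 4 (beyond the scatter). Compound 4 is estimated at 35%, with a range from 15% to 60%. The range is kept wide, since it is supported by a single comparison rather than by a measured step.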

Compound 4, a percentage reported as activity, at one concentration (the size of the read-out at that concentration, not a potency): 0%
For compound 4 the middle estimate is 35 percentage points above the measured one; measured number below the stated range.
By their numbers in this assay, from the lowest: compounds 3 and 4 (each within the scatter of the next); then compound 1; then compound 2.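

In this assay, for the compounds shown here, this is the first step that can be read at a single place: hepta-1,4-dien-1-yl in place of heptyl, on a saturated chain carbon, two bonds along the chain from a double-bonded chain carbon, gives a number 58.3 percentage points lower from compound 2 to compound 4 (beyond the scatter). Going by these compounds alone, the leaving and entering groups have the same heavy-atom count, and neither carries a ring, hydrogen-bond donors, hydrogen-bond acceptors or a net charge, so the two double bonds are the counted difference between them, something the earlier compounds could not isolate because no two of them differed in one place. Nothing at hand explains the size of this step.

The compounds shown leave open whether a single double bond in this chain would give a step of similar size, and whether the placement of the double bonds or their cis geometry matters. They also leave open what a longer chain, a chain ending in a carboxylic acid or a chain ending in an amine would give in place of hepta-1,4-dien-1-yl at this carbon.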